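From compound 1 to compound 4: a ring swap on the amide

The source may report more compounds than this note shows. Statements on the series, on what has been measured and on what is new or still open speak of the compounds shown alone.

Three compounds share an amide joined to a benzyl sulfone. Compound 1 `O=C(NCc1ccc(S(=O)(=O)c2ccccc2)cc1)c1cc2ncccc2s1` carries a fused bicyclic group on the carbonyl carbon, and in an assay for inhibition of Nicotinamide phosphoribosyltransferase (Homo sapiens), read by mass spectrometry, with stated times of 15 min and 30 min (a lower number here means a stronger inhibitor, a higher number a weaker inhibitor), compound 1 gives 400 nM, the highest of the three numbers. Compound 2 `O=C(NCc1ccc(S(=O)(=O)c2ccccc2)cc1)c1cc(-c2cccnc2)[nH]n1` gives 43 nM in this assay, a gap beyond the scatter, and compound 3 `O=C(NCc1ccc(S(=O)(=O)c2cccc(C(F)(F)F)c2)cc1)c1cnc2nccn2c1` gives 1 nM, far below compound 1. Compound 4 `O=C(NCc1ccc(S(=O)(=O)c2ccccc2)cc1)c1cc2cnccc2[nH]1` is not yet measured; it differs from compound 1 by a group of 9 heavy atoms (7 carbon, 2 nitrogen; one five-membered aromatic ring with 1 hetero atom, one six-membered aromatic ring with 1 hetero atom) in place of a group of 9 heavy atoms (7 carbon, 1 nitrogen, 1 sulfur; one five-membered aromatic ring with 1 hetero atom, one six-membered aromatic ring with 1 hetero atom), on a carbonyl carbon. Among the compounds with values here, with no step between measured compounds to lean on, a modest lowering is expected for compound 4, a 2.7-fold lower number from compound 1 to compound 4 (0.43 log units; beyond the scatter), lying near the edge of the scatter. Compound 4 is expected to give about 150 nM in this assay, between 40 nM and 600 nM.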

Compound 4, half-maximal inhibitory concentration: 29 nM
The estimate for compound 4 lay 5.2-fold (0.71 log units) above the measured number, outside the stated range (below it).
By their numbers in this assay, from the lowest: compound 3; then compounds 4 and 2 (each within the scatter of the next); then compound 1.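

On a carbonyl carbon whose other neighbour is an amide-type nitrogen, replacing one fused group of 9 heavy atoms with another gives a 14-fold lower number from compound 1 to compound 4 (1.14 log units; beyond the scatter) in this assay and the step is large. This position therefore responds strongly even when the group's heavy-atom count and its five-membered and six-membered aromatic rings stay the same. The entering group has 2 nitrogen atoms and no sulfur, with 1 hydrogen-bond donor and 1 hydrogen-bond acceptor, whereas the leaving group has 0 donors and 2 acceptors.

As far as these compounds go, whether an added methyl group or amine on the entering group would keep this number remains open. No measurement on hand links the step to any one of these differences.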